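Alkyl extension on the furan ring of compound 3

The compounds below may be only part of what the source reports. "The series", "measured", "known", "first", "only" and "open" are said of these compounds alone.

Measured so far in an assay on CHO cells for displacement of a labelled ligand from C-X-C chemokine receptor type 1 (Homo sapiens); on this read-out lower numbers stand for stronger inhibition and higher numbers for weaker inhibition:
compound 1, `CC[C@@H](Nc1c(Nc2cccc(C(=O)N(C)C)c2O)c(=O)c1=O)c1ccc(C)s1`, compound 1 gives 146 nM
compound 2, `CC[C@@H](Nc1c(Nc2cccc(C(=O)N(C)C)c2O)c(=O)c1=O)c1sccc1C`, compound 2 gives 123 nM
compound 3, `CCc1coc([C@@H](CC)Nc2c(Nc3cccc(C(=O)N(C)C)c3O)c(=O)c2=O)c1`, compound 3 gives 7 nM

Compound 3 stands lowest of the three numbers; the steps of a 21-fold lower number from compound 1 to compound 3 (1.32 log units; beyond the scatter) and an 18-fold lower number from compound 2 to compound 3 (1.24 log units; beyond the scatter) are both large and beyond the scatter, while the step of a 1.2-fold lower number from compound 1 to compound 2 (0.07 log units; within the scatter) lies within it. All three steps exchange the aromatic ring on the chain carbon; none of them alters an alkyl group on a ring that is kept.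

Compound 4, `CCCCc1coc([C@@H](CC)Nc2c(Nc3cccc(C(=O)N(C)C)c3O)c(=O)c2=O)c1`, keeps the furan of compound 3 and differs only by ethyl in place of hydrogen on a saturated chain carbon, two bonds along the chain from an aromatic carbon. Within the data shown here, no measured pair tests this kind of change, so the expectation rests on compound 3 alone. Among the measured compounds shown here, the only alkyl-related information, the shift of a methyl on the thiophene from compound 1 to compound 2, stayed within the scatter, which gives a weak hint that small alkyl changes on the ring are tolerated, but that pair changes the ring position, not the chain length. The step of a 1.3-fold higher number from compound 3 to compound 4 (0.11 log units; within the scatter) is therefore expected to be small and of uncertain direction, most likely within the scatter. Compound 4 is estimated at 9 nM, with a range from 3 nM to 30 nM.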

Compound 4, inhibition constant: 34 nM
The estimate for compound 4 lay 3.8-fold (0.58 log units) below the measured number; measured number above the stated range.
By their numbers in this assay, from the lowest: compound 3; then compound 4; then compounds 2 and 1 (each within the scatter of the next).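

Notes on the furan alkyl chain: in this assay, the change from 4-ethylfuran-2-yl to 4-butylfuran-2-yl is the first in the series to alter the alkyl length on a ring that is kept, and it gives a 4.9-fold higher number from compound 3 to compound 4 (0.69 log units; beyond the scatter). The number at this position therefore responds to chain length, a sensitivity that the earlier ring exchanges could not reveal. The 4-butylfuran-2-yl group still compares well with both methylthiophene groups, with a 3.6-fold lower number from compound 2 to compound 4 (0.56 log units; beyond the scatter) and a 4.3-fold lower number from compound 1 to compound 4 (0.63 log units; beyond the scatter), so the added ethyl gives up only part of the furan's advantage. The data at hand offer no explanation for the step from ethyl to butyl.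

Going by these compounds, with only ethyl and butyl on the furan, the shape of the chain-length trend remains open: a propyl group or a longer chain such as hexyl would show whether the number rises steadily or levels off. Also open, on these data alone, is whether a hydroxyl group, an amine or a carboxylic acid at the end of the chain would be accepted, and whether the same extension on a thiophene would give a similar step.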